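Pyrazolyl enones on lung carcinoma cells: methoxyphenyl variant

The source may report more compounds than this note shows. Statements on the series, on what has been measured and on what is new or still open speak of the compounds shown alone.

Measured so far:
compound 1 `COc1cc(-c2cc(/C=C/C(=O)c3ccc(N)cc3)[nH]n2)cc(OC)c1OC`: -83%
compound 2 `COc1cc(-c2cc(/C=C/C(=O)c3ccc(Cl)c(Cl)c3)[nH]n2)cc(OC)c1OC`: -65%
compound 3 `COc1ccc(-c2cc(/C=C/C(=O)c3ccc(N)cc3)[nH]n2)cc1OC`: -92%

All three share a core carrying a trimethoxyphenyl or dimethoxyphenyl group on one side and an aryl ketone on the other, tested in a functional assay on NCI-H522 cells (Homo sapiens) for cytotoxicity, read by sulforhodamine B assay, with a stated time of 48 h, tested at 100 uM; a higher number here means a weaker effect of the compound at the concentration tested, a lower number a stronger effect. Compound 2 stands highest of the three numbers: a number 18 percentage points higher from compound 1 to compound 2 (beyond the scatter) separates it from compound 1, and compound 3 lies further off still. The change from compound 1 to compound 3, a number 9 percentage points lower from compound 1 to compound 3 (within the scatter), stays within the scatter, so the methoxy count on the far ring is not resolved here.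

Compound 4 `COc1ccc(C(=O)/C=C/c2cc(-c3cc(OC)c(OC)c(OC)c3)n[nH]2)cc1` is the next variant, and it differs from compound 2 by 4-methoxyphenyl in place of 3,4-dichlorophenyl on a carbonyl carbon. Among the measured compounds shown here, the only measured step that bears on the aryl ketone is a number 18 percentage points higher from compound 1 to compound 2 (beyond the scatter), where 4-aminophenyl gave way to 3,4-dichlorophenyl; that step was modest and ran upward. For the measured compounds named here, compound 4 carries 4-methoxyphenyl, which no measured compound holds, so a direct reading is absent. Returning from 3,4-dichlorophenyl toward a singly substituted ring is expected to bring a step back downward, though of uncertain size. The expected step is a number 13 percentage points lower from compound 2 to compound 4 (beyond the scatter) for compound 4. Compound 4 is therefore estimated at -78%, with a range from -95% to -60%.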

Compound 4, a percentage reported as activity, at one concentration (the size of the read-out at that concentration, not a potency): -62%
For compound 4 the middle estimate is 16 percentage points below the measured one; the measured number falls inside the stated range.
By their numbers in this assay, from the lowest: compounds 3 and 1 (each within the scatter of the next); then compounds 2 and 4 (each within the scatter of the next).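

On the carbonyl carbon, 4-methoxyphenyl in place of 3,4-dichlorophenyl gives a number 3 percentage points higher from compound 2 to compound 4 (within the scatter) in this assay, so this change does not separate the two rings, although one brings a methoxy oxygen and the other two chlorines. The amino group now looks more distinct: methoxy in place of amino on an aromatic carbon gives a number 21 percentage points higher from compound 1 to compound 4 (beyond the scatter), and the earlier step of a number 18 percentage points higher from compound 1 to compound 2 (beyond the scatter) runs the same way, so among the trimethoxyphenyl compounds the 4-aminophenyl ring of compound 1 stands apart from two quite different replacements. Nothing available accounts for this separation or for the lack of one between compound 2 and compound 4.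

As far as these compounds go, it remains open whether the separation depends on the amino group itself or would persist with a dimethylamino or acetamido group in its place. Also open, from the compounds shown here alone, is whether the 4-methoxyphenyl and 3,4-dichlorophenyl rings would stay unresolved on the dimethoxyphenyl variant represented by compound 3, whose reading in this assay is so far tied to the 4-aminophenyl ring alone.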